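This account rests on a few compounds, and the source may have more. Where it says the series, first, only, none or still open, it means among the compounds named here.

Measured compounds:
compound 1 `O=C(O)Cc1sc(C(c2ccc(F)cc2)c2ccc(F)cc2)nc1-c1ccnc(F)c1`: 4.7 nM
compound 2 `O=C(O)Cc1sc(C(c2ccccc2)c2ccccn2)nc1-c1ccc(Cl)cc1`: 1900 nM

In an in vitro functional assay on HEK285-7 cells for antagonist activity at prostaglandin D2 receptor 2 (Homo sapiens), read by BRET and beta-arrestin recruitment (on this read-out higher numbers stand for weaker inhibition and lower numbers for stronger inhibition), compound 1 gives 4.7 nM, the lowest of the two numbers. Compound 2 gives 1900 nM in this assay, a gap from compound 1 that lies well beyond the usual scatter; the two structures differ in several places, so only the two values themselves can be compared. Compound 3 `Nc1cc(-c2nc(C(c3ccc(F)cc3)c3ccc(F)cc3)sc2CC(=O)O)cc(F)n1` has not yet been measured in this assay. It differs from compound 1 in one place: amino in place of hydrogen on an aromatic carbon. Within the data shown here, since no single-change step between measured compounds is available, the effect of this change rests on expectation alone. A small step is expected, a 1.7-fold higher number from compound 1 to compound 3 (0.23 log units; within the scatter), within or only slightly beyond the scatter and, if anything, toward a higher number. Compound 3 is therefore estimated at 8 nM in this assay, with a range from 2 nM to 35 nM.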

Compound 3, half-maximal inhibitory concentration: 1400 nM
Compound 3: the middle estimate sits 180-fold (2.24 log units) below what was measured; measured number above the stated range.
By their numbers in this assay, from the lowest: compound 1; then compounds 3 and 2 (each within the scatter of the next).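

In this assay, amino in place of hydrogen on the aromatic carbon next to the ring nitrogen, turning 2-fluoropyridin-4-yl into 2-amino-6-fluoropyridin-4-yl, gives a 300-fold higher number from compound 1 to compound 3 (2.47 log units; beyond the scatter). Among these compounds, this is the first change in one place that can be read here, and it shows that this carbon is far from indifferent to substitution. A single added heavy atom is enough to remove most of the inhibition seen with compound 1. Nothing at hand accounts for the size of this step.

Going by these compounds, whether the loss is particular to amino or would also follow from a methyl or a methoxy group on this carbon remains open. Also open, on these data alone, is whether the step would be as large with a different group in place of the fluoro group on the same ring.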